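Replacing anilino by 4-methylpiperidin-1-yl: an untested step

The source may hold more compounds than are shown below. What is called first, only, known or untested is meant among the compounds shown, and "the series" means these compounds.

Measured so far:
compound 1, `Nc1ccccc1NC(=O)/C=C/c1ccc(Cn2cnc3c(Nc4ccccc4)nc(Cl)nc32)cc1`: 30.9%
compound 2, `Nc1ccccc1NC(=O)c1ccc(Cn2cnc3c(Nc4ccccc4)nc(Cl)nc32)cc1`: 83.5%

In a functional assay on HCT-116 cells (Homo sapiens) for antiproliferative activity, read by CCK-8 assay, with a stated time of 72 h, tested at 8 uM (on this read-out lower numbers stand for a weaker effect and higher numbers for a stronger effect at the one concentration tested), compound 1 gives 30.9%. In this assay compound 2 gives 83.5%. Going by the values given here, compound 2 thus stands highest of the two numbers, and the only other compound, compound 1, lies far below it: a number 52.6 percentage points higher from compound 1 to compound 2 (beyond the scatter). That single measured step exchanged 2-((2-aminophenyl)carbamoyl)ethenyl for (2-aminophenyl)carbamoyl on an aromatic carbon, that is, it shortened the link carrying the amide.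

Compound 3, `CC1CCN(c2nc(Cl)nc3c2ncn3Cc2ccc(C(=O)Nc3ccccc3N)cc2)CC1`, is not yet measured. It differs from compound 2 at one place: 4-methylpiperidin-1-yl in place of anilino on an aromatic carbon. Among the compounds with values here, the measured step touched only the amide link and left this position of the shared core unchanged, so no measured step bears on the present change, and its direction cannot be read from the data. The size of the step is therefore taken as moderate and uncertain. Compound 3 is expected at 70%, within 40% to 90%, meaning an estimated a number 13.5 percentage points lower from compound 2 to compound 3 (beyond the scatter).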

Compound 3, a percentage reported as inhibition, at one concentration (the size of the read-out at that concentration, not a potency): 78.6%
For compound 3 the middle estimate is 8.6 percentage points below the measured one, and the stated range covers the measured number.
By their numbers in this assay, from the lowest: compound 1; then compounds 3 and 2 (each within the scatter of the next).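

In this assay, placing 4-methylpiperidin-1-yl instead of anilino on this aromatic carbon, next to the ring nitrogen, gives a number 4.9 percentage points lower from compound 2 to compound 3 (within the scatter), so the two compounds cannot be told apart at the one concentration tested. Going by these compounds alone, this is the first information about this position, and it shows that a six-membered aromatic ring of carbon only can give way to a six-membered non-aromatic ring with 1 hetero atom, and 1 hydrogen-bond donor to 0 hydrogen-bond donors, without a read-out change beyond the scatter in this single pair. No measurement at hand accounts for this outcome.

The compounds shown leave open whether this tolerance extends to other groups at the same carbon, such as morpholin-4-yl, dimethylamino or benzylamino, and whether removing the 4-methyl group from the piperidine ring would matter. They also leave open whether the same exchange would give a similar outcome with the 2-((2-aminophenyl)carbamoyl)ethenyl group of compound 1, and whether compound 2 and compound 3 would still match at lower concentrations, where a single reading at one concentration offers no guide.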